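The source may report more compounds than this note shows. Statements on the series, on what has been measured and on what is new or still open speak of the compounds shown alone.

Compound 1 `CC#CCn1c(N2CCC[C@@H](N)C2)cc(=O)n(Cc2cc(C(=O)O)ccc2Br)c1=O` carries a 2-bromo-5-carboxyphenyl group on the saturated chain carbon bound to an aromatic nitrogen. In an assay on isolated protein for inhibition of Dipeptidyl peptidase 9 (Homo sapiens), read by fluorescence, with stated times of 15 min and 20 min (on this read-out lower numbers stand for stronger inhibition and higher numbers for weaker inhibition), compound 1 returns only a limit, > 100 nM. Compound 2 `CC#CCn1c(N2CCC[C@@H](N)C2)cc(=O)n(Cc2ccc(F)c(C(=O)O)c2)c1=O` likewise gives only a limit in this assay, > 100 nM. Compound 3 `CC#CCn1c(N2CCC[C@@H](N)C2)cc(=O)n(Cc2cc(Br)cc(C(=O)O)c2)c1=O` also stands at a limit in this assay, > 100 nM. The steps a step that the two limits leave unreadable from compound 1 to compound 2, a step that the two limits leave unreadable from compound 1 to compound 3 and a step that the two limits leave unreadable from compound 2 to compound 3 therefore cannot be sized; every value shown rests at the limit of > 100 nM in this assay, at which 3 of the 3 values shown sit. Compound 4 `CC#CCn1c(N2CCC[C@@H](N)C2)cc(=O)n(Cc2ccc(Br)c(C(=O)O)c2)c1=O` differs from compound 3 by 4-bromo-3-carboxyphenyl in place of 3-bromo-5-carboxyphenyl on a saturated chain carbon bound to an aromatic nitrogen. With all measured steps unreadable, no movement beyond the scatter in this assay is expected for compound 4, the estimated step being a step that the limit leaves unreadable from compound 3 to compound 4. Compound 4 is expected near 250 nM, within 60 nM to 1500 nM, most probably again only a limit.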

Compound 4, half-maximal inhibitory concentration: > 100 nM
Compound 4 gave a limit, no number; the forecaster's own chance of this, stated with the estimate: 80%; the middle value does not contradict the limit.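

In this assay compound 4 gives only a limit, > 100 nM, so its steps from compound 1, compound 2 and compound 3 cannot be read: the limit of > 100 nM in this assay, at which 4 of the 4 values shown sit. The compounds shown leave open how strongly any of the four inhibits, and whether moving the bromo and carboxy groups changes this at all.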